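Methyl to benzylsulfonyl on the aromatic nitrogen

The source may report more compounds than this note shows. Statements on the series, on what has been measured and on what is new or still open speak of the compounds shown alone.

The compounds share one core bearing a 4-methoxyphenyl group and differ only in what sits on the aromatic nitrogen of that core. Compound 1 `COc1ccc(-c2cc(=O)c3c(OC)cc(OC)cc3n2C)cc1` carries a methyl there; in a functional assay on KOPN-8 cells (Homo sapiens) for antiproliferative activity, with a stated time of 72 h (a lower number here means that less compound is needed, a higher number that more compound is needed for the effect), compound 1 gives 30000 nM. Among the three measured values this is the only number; the other two are limits. Compound 2 `COc1ccc(-c2cc(=O)c3c(OC)cc(OC)cc3n2S(=O)(=O)c2cccc([N+](=O)[O-])c2)cc1` carries a 3-nitrophenyl on a sulfonyl sulfur, and in this assay compound 2 gives > 39600 nM, which is a limit of the assay and not a number. Compound 3 `COc1ccc(-c2cc(=O)c3c(OC)cc(OC)cc3n2S(=O)(=O)c2cc(F)c(F)c(F)c2)cc1` carries a 3,4,5-trifluorophenyl on a sulfonyl sulfur, and in this assay compound 3 gives > 65500 nM, again a limit. The step that the two limits leave unreadable from compound 2 to compound 3 therefore has no readable size. Compound 4 `COc1ccc(-c2cc(=O)c3c(OC)cc(OC)cc3n2S(=O)(=O)Cc2ccccc2)cc1` differs from compound 1 by benzylsulfonyl in place of methyl on an aromatic nitrogen. Going by the values given here, no measured step follows this change directly; what the data show is that both compounds with a sulfonyl group on the nitrogen sit at a limit, as the limit of > 39600 nM in this assay, at which 1 of the 3 values shown sits, and the limit of > 65500 nM in this assay, at which 1 of the 3 values shown sits, record, while compound 1 with its methyl does not. A weakening step is therefore expected, of uncertain size. The expected change is a 2.0-fold higher number from compound 1 to compound 4 (0.30 log units; within the scatter). Compound 4 is estimated at 60000 nM, between 20000 nM and 150000 nM, with a real chance that only a limit is reported.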

Compound 4, half-maximal effective concentration: > 34400 nM
Compound 4 gave a limit, no number; the forecaster's own chance of this, stated with the estimate: 65%; the middle value is on the limit's open side.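

In this assay compound 4 gives > 34400 nM, which is a limit of the assay and not a number. Benzylsulfonyl in place of methyl on the aromatic nitrogen gives an at least 1.1-fold higher number from compound 1 to compound 4 (0.05 log units; that floor lies within the scatter), and because only this floor is known and it lies within the scatter, the step alone does not establish that compound 4 is weaker than compound 1, while the steps among compound 2, compound 3 and compound 4 cannot be read. What is new is that benzyl on the sulfonyl sulfur joins 3-nitrophenyl and 3,4,5-trifluorophenyl in ending at a limit, so all three sulfonyl compounds shown lack a number and only compound 1, with its methyl, has one, and the new limit is this one: the limit of > 34400 nM in this assay, at which 1 of the 4 values shown sits.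

Going by these compounds, the true size of the change from methyl to benzylsulfonyl stays open, since the number for compound 4 could lie close to that of compound 1 or far beyond it. Also open, on these data alone, is how the nitrogen responds to groups without a sulfonyl, such as an ethyl, a longer carbon chain or a chain ending in an amine or a carboxylic acid.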